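Swapping pyridin-4-yl for 4-bromophenyl: what to expect

This account rests on a few compounds, and the source may have more. Where it says the series, first, only, none or still open, it means among the compounds named here.

Measured in an ADME assay on J774 cells (Mus musculus) for cytotoxicity, read by resazurin assay, with a stated time of 72 h; a lower number here means that less compound is tolerated, a higher number that more compound is tolerated:
- Compound 1 `C/C(=N\N=c1\scc(-c2ccccc2)n1-c1ccccc1)c1ccc(Cl)c(Cl)c1`: > 50000 nM (a limit, not a number)
- Compound 2 `C/C(=N\Nc1nc(-c2ccncc2)cs1)c1ccc(Cl)c(Cl)c1`: 39800 nM
- Compound 3 `C/C(=N\Nc1nc(-c2ccc(Cl)c(Cl)c2Cl)cs1)c1ccc(Cl)c(Cl)c1`: 21300 nM

Only two of these results are exact numbers. Compound 2 gives 39800 nM and compound 3 gives 21300 nM, and these two values lie within the usual scatter of each other, so neither can be ranked over the other. Compound 1 gives > 50000 nM, which is a limit of the assay and not a number.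

The next compound to be tested is compound 4 `C/C(=N\Nc1nc(-c2ccc(Br)cc2)cs1)c1ccc(Cl)c(Cl)c1`. It has 4-bromophenyl in place of pyridin-4-yl on an aromatic carbon of a five-membered aromatic ring with 1 nitrogen and 1 sulfur. The change counts as follows: 4-bromophenyl in place of pyridin-4-yl on an aromatic carbon.

Within the data shown here, no measured pair shows what this exchange does by itself. Among the measured compounds shown here, the expectation therefore leans on compound 3 at 21300 nM, the only other exact number available. A modest move toward a lower number in this assay is expected, with no change beyond the usual scatter being the likeliest reading. The expected step is a 1.7-fold lower number from compound 2 to compound 4 (0.24 log units; within the scatter). For compound 4 the estimated value is 23000 nM, with an expected range from 9000 nM to 50000 nM.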

Compound 4, half-maximal cytotoxic concentration: > 50000 nM
Compound 4: no number, only a limit; the forecaster's own chance of this, stated with the estimate: 20%; at least 2.1-fold (0.33 log units) between middle value and limit.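

In this assay compound 4 gives > 50000 nM, which is a limit of the assay and not a number. Among these compounds, the exchange of pyridin-4-yl for 4-bromophenyl, on the aromatic carbon next to the ring nitrogen, is the first change in a single place that can be read here, and it gives an at least 1.2-fold higher number from compound 2 to compound 4 (0.09 log units; that floor lies within the scatter), so only the direction is indicated, and even that floor does not clear the usual scatter. The result also shows that the hetero atom of pyridin-4-yl, counted as a hydrogen-bond acceptor, can be absent from this group while the read-out stays at the top of what the assay reports, and the true size of the step stays hidden: the limit of > 50000 nM in this assay, at which 2 of the 4 values shown sit.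

The compounds shown leave open how far past this limit compound 4 lies, and whether the bromine or the ring of carbon only matters more, as the two differences arrive together. How an amine or a carboxylic acid in place of the bromine would read at this position also remains an open question.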